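The source may hold more compounds than are shown below. What is called first, only, known or untested is meant among the compounds shown, and "the series" means these compounds.

Working notes on the series. All three measured compounds share one core and differ only in the chain on the aromatic nitrogen. Compound 1 `O=C1c2c[n+]([O-])c3ccccc3c2C(=O)c2c1c1ccccc1n2Cc1cn(C[C@H](O)CO)nn1` reaches only the limit of a functional assay on SH-SY5Y cells (Homo sapiens) for cytotoxicity, read by MTT assay, with a stated time of 72 h; on this read-out lower numbers stand for stronger inhibition and higher numbers for weaker inhibition: compound 1 gives > 1000 nM, which is a limit of the assay and not a number (the limit of > 1000 nM in this assay, at which 1 of the 3 values shown sits). Compound 2 `O=C1c2c[n+]([O-])c3ccccc3c2C(=O)c2c1c1ccccc1n2CCN1CCCC1` gives 520 nM in this assay, and compound 3 `O=C1c2c[n+]([O-])c3ccccc3c2C(=O)c2c1c1ccccc1n2CCCCN1CCNCC1` gives 1240 nM.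

Compound 4 `CN1CCN(CCCCCCn2c3c(c4ccccc42)C(=O)c2c[n+]([O-])c4ccccc4c2C3=O)CC1` differs from compound 1 by 5-(4-methylpiperazin-1-yl)pentyl in place of 1-(2,3-dihydroxypropyl)-1H-1,2,3-triazol-4-yl on a saturated chain carbon bound to an aromatic nitrogen. Among the compounds with values here, three measured steps bear on it. From compound 1 the data show an at least 1.9-fold lower number from compound 1 to compound 2 (0.28 log units; that floor lies within the scatter) and a step that the limit leaves unreadable from compound 1 to compound 3. Between the two basic-amine chains the data show a 2.4-fold higher number from compound 2 to compound 3 (0.38 log units; beyond the scatter). Compound 4 carries a basic amine on a longer saturated chain, so a number in the region of compound 2 and compound 3 is expected, with the chance that the limit is met again.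

Compound 4 is therefore estimated at 800 nM, with a range from 300 nM to 2500 nM. That estimate means an expected step of an at least 1.2-fold lower number from compound 1 to compound 4 (0.09 log units; that floor lies within the scatter).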

Compound 4, half-maximal inhibitory concentration: 920 nM
The estimate for compound 4 lay 1.2-fold (0.06 log units) below the measured number; measured number inside the range.
By their numbers in this assay, from the lowest: compounds 2, 4 and 3 (each within the scatter of the next, the first and the last beyond it).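

With 5-(4-methylpiperazin-1-yl)pentyl on the saturated chain carbon bound to an aromatic nitrogen, the series gains a further chain with a measured number, and that number does not separate it from either earlier basic-amine chain: a 1.3-fold lower number from compound 3 to compound 4 (0.13 log units; within the scatter) and a 1.8-fold higher number from compound 2 to compound 4 (0.25 log units; within the scatter) both lie within the scatter. The change from piperazin-1-yl to 2-(4-methylpiperazin-1-yl)ethyl, four bonds along the chain from the aromatic nitrogen, therefore shows no readable effect. Against compound 1, whose value is a limit and not a number, the result gives only an at least 1.0-fold lower number from compound 1 to compound 4 (0.03 log units; that floor lies within the scatter): the limit of > 1000 nM in this assay, at which 1 of the 4 values shown sits.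

Open, on these data alone, is whether a morpholine or a carboxylic acid at the end of the chain would move the number beyond the scatter of compounds 2, 3 and 4. Also open, as far as these compounds go, is the true size of the step away from the 1-(2,3-dihydroxypropyl)-1H-1,2,3-triazol-4-yl group of compound 1.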